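The compounds below may be only part of what the source reports. "The series", "measured", "known", "first", "only" and "open" are said of these compounds alone.

Among the compounds with values here, in a functional assay on HT cells (Homo sapiens) for antiproliferative activity, read by fluorescence, with a stated time of 72 h (on this read-out higher numbers stand for weaker inhibition of growth and lower numbers for stronger inhibition of growth), compound 3 `CC(C)c1n[nH]c2c(NCc3ccc(-c4ccccn4)cc3)nc(SCCNC(N)=O)nc12` gives 240 nM, the lowest number so far. Compound 1 `CC(C)c1n[nH]c2c(NCc3ccc(-c4ccccn4)cc3)nc(SCC(C)(C)O)nc12` gives 507 nM, and compound 2 `CC(C)c1n[nH]c2c(NCc3ccc(-c4ccccn4)cc3)nc(SC3CCCC3O)nc12` gives 567 nM. The gap here is a 1.1-fold higher number from compound 1 to compound 2 (0.05 log units; within the scatter). Compound 4 `C=CCSc1nc(NCc2ccc(-c3ccccn3)cc2)c2[nH]nc(C(C)C)c2n1` is still unmeasured and differs from compound 3 by vinyl in place of ureidomethyl on a saturated chain carbon bound to a sulfur, with vinyl in place of ureidomethyl on a saturated chain carbon bound to a sulfur. Within the data shown here, no measured compound carries the allyl group, so the evidence is indirect. The nearest guides are the two steps that introduce the urea-bearing chain: a 2.1-fold lower number from compound 1 to compound 3 (0.32 log units; beyond the scatter) and a 2.4-fold lower number from compound 2 to compound 3 (0.37 log units; beyond the scatter). Removing that chain should therefore bring a modest rise in this assay, and the expected change is a 1.8-fold higher number from compound 3 to compound 4 (0.24 log units; within the scatter). The estimate for compound 4 is 420 nM, with an expected range of 160 nM to 1100 nM.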

Compound 4, concentration for 50% growth inhibition: 1010 nM
For compound 4 the middle estimate is 2.4-fold (0.38 log units) below the measured one; measured number inside the range.
By their numbers in this assay, from the lowest: compound 3; then compounds 1, 2 and 4 (each within the scatter of the next).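

In this assay, allyl in place of 2-ureidoethyl on the sulfur gives a 4.2-fold higher number from compound 3 to compound 4 (0.62 log units; beyond the scatter) and so removes the urea, leaving a chain with no hydrogen-bond donors or acceptors. Compound 4 sits within the scatter of the two hydroxyl-bearing compounds, with a 1.8-fold higher number from compound 2 to compound 4 (0.25 log units; within the scatter) and a 2.0-fold higher number from compound 1 to compound 4 (0.30 log units; within the scatter) as the printed gaps, so only compound 3 stands apart at this position. No measured evidence explains this difference.

Still open, from the compounds shown here alone, is whether an amine or a carboxylic acid on the same chain would match the urea, and whether a longer chain carrying the urea would change the number.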